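A few compounds are considered here, and "the series" means these few. Any claim that something is new, unique, unknown or untested is made for them only; others in the source may bear on it.

Measured so far:
- compound 1 `CCN(CC)CC(=O)N1N=C(C)CC1c1ccccc1OC(C)=O`: 33200 nM
- compound 2 `CC(=O)Oc1ccccc1C1CC(C)=NN1C(=O)CN(C(C)C)C(C)C`: 34100 nM
- compound 3 `CCC(=O)N1N=C(c2cc3ccccc3oc2=O)CC1c1ccccc1`: 9610 nM

In a functional assay on HepG2 cells (Homo sapiens) for cytotoxicity, read by MTT assay, with a stated time of 48 h (a lower number here means a stronger inhibitor, a higher number a weaker inhibitor), compound 3 stands lowest of the three numbers, beyond the scatter from both compound 1 and compound 2. Compound 4 `CC1CCCCN1CC(=O)N1N=C(c2cc3ccccc3oc2=O)CC1c1ccccc1` is not yet measured in this assay. It differs from compound 3 in one place: 2-methylpiperidin-1-yl in place of methyl on a saturated chain carbon bound to a carbonyl carbon.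

Within the data shown here, the only measured step that touches the same place is a 1.0-fold higher number from compound 1 to compound 2 (0.01 log units; within the scatter), which exchanged one amine for another on that saturated chain carbon and moved the number not at all. That step swaps two amines; the step to compound 4 instead brings an amine in where a methyl was, so the bearing is indirect. Compounds 1 and 2, which both carry an amine on that chain carbon, sit higher than compound 3, but they differ from compound 3 in more than that one place, so no single step can be read from them. The expectation for the step from compound 3 to compound 4 in this assay is therefore a change of modest size, if any, with the direction uncertain: a 1.2-fold higher number from compound 3 to compound 4 (0.10 log units; within the scatter). Compound 4 is estimated at 12000 nM, within a range of 4000 nM to 40000 nM.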

Compound 4, half-maximal inhibitory concentration: "not active" (no number reported)
Nothing numeric was reported for compound 4; there is nothing to compare the estimate with.
By their numbers in this assay, from the lowest: compound 3; then compounds 1 and 2 (each within the scatter of the next).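

In this assay, among these compounds, compound 4 is reported as "not active" with no number, so no step from compound 3 to compound 4 can be read. The compounds shown leave open how far 2-methylpiperidin-1-yl in place of methyl moves the number. No evidence bearing on this result is available.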